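Methoxy for Fluoro on a Shared Indole-Derived Core

The compounds below may be only part of what the source reports. "The series", "measured", "known", "first", "only" and "open" are said of these compounds alone.

Three compounds have so far been measured in a functional assay on A549 cells (Homo sapiens) for cytotoxicity, read by WST assay, with a stated time of 48 h; on this read-out higher numbers stand for weaker inhibition and lower numbers for stronger inhibition:
Compound 1 `COc1ccc2[nH]cc(/C=C(\C#N)C(=O)c3c[nH]c4cc(F)ccc34)c2c1` gives 26300 nM.
Compound 2 `N#C/C(=C\c1cn(Cc2ccc(Cl)cc2)c2ccccc12)C(=O)c1c[nH]c2cc(F)ccc12` reaches only a limit of the assay, > 50000 nM.
Compound 3 `COc1ccc2c(C(=O)/C(C#N)=C/c3cn(Cc4ccc(Cl)cc4)c4ccccc34)c[nH]c2c1` likewise reaches only a limit of the assay, > 50000 nM.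

Compound 1 is the only one of the three with a measured number in this assay; the other two values are limits, not numbers. Compound 2 and compound 3 are joined by one structural change, (methoxy in place of fluoro on an aromatic carbon). The size of that step, a step that the two limits leave unreadable from compound 2 to compound 3, cannot be read, because both values sit at the limit of > 50000 nM in this assay, at which 2 of the 3 values shown sit. How the core of compound 1 differs from the core of compound 2 is not broken down here.

Compound 4 `COc1ccc2c(C(=O)/C(C#N)=C/c3c[nH]c4ccc(OC)cc34)c[nH]c2c1` has not yet been measured. Within the data shown here, it arises from compound 1 by the same change as the one seen from compound 2 to compound 3, namely (methoxy in place of fluoro on an aromatic carbon). Since the earlier step is unreadable, the expectation for compound 4 rests only on compound 1 and its value of 26300 nM, with a wide range. The step expected from compound 1 to compound 4 is a 1.1-fold higher number from compound 1 to compound 4 (0.06 log units; within the scatter). For compound 4 in this assay the estimate is 30000 nM, expected to lie between 9000 nM and 100000 nM.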

Compound 4, half-maximal inhibitory concentration: 5500 nM
For compound 4 the middle estimate is 5.5-fold (0.74 log units) above the measured one; the measured number lies below the stated range.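

On the core of compound 1, methoxy in place of fluoro in this assay gives a 4.8-fold lower number from compound 1 to compound 4 (0.68 log units; beyond the scatter), so on this core the change goes with stronger inhibition. This is a single readable step, so it shows what the change did on one core and does not show that the same gain carries over to another core, nor why the number moved. The matching step between compound 2 and compound 3 cannot be read, because each of these two compounds gives a limit and not a number: the limit of > 50000 nM in this assay, at which 2 of the 4 values shown sit.

The compounds shown leave open how an amine, a carboxylic acid or a longer chain such as ethoxy would compare with fluoro and methoxy on the same aromatic carbon of the shared core. They also leave open whether the change would give a step of similar size on a further core whose values fall clear of the limit.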